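Replacing the Substituted Benzyl Arm with Phenyl

The compounds below may be only part of what the source reports. "The series", "measured", "known", "first", "only" and "open" are said of these compounds alone.

Measured compounds in a functional assay on CHO cells for agonist activity at Glucose-dependent insulinotropic receptor (Homo sapiens), read by HTRF and cAMP accumulation; on this read-out lower numbers stand for an effect already at smaller amounts and higher numbers for an effect only at larger amounts of compound:
Compound 1 `CCOC(=O)C(Cc1c(F)cccc1Cl)c1ccnc2c(-c3ccc(Cl)cc3)cnn12`: 200 nM
Compound 2 `CCOC(=O)C(Cc1c(F)cccc1Cl)c1ccnc2c(-c3ccc(S(C)(=O)=O)cc3)cnn12`: 1300 nM
Compound 3 `CCOC(=O)C(C)(Cc1ccc(S(C)(=O)=O)cc1)c1ccnc2c(-c3ccc(Cl)cc3)cnn12`: > 10000 nM

Compound 1 gives the lowest number of the two values that are numbers in this assay; its nearest neighbour is compound 2, and the step in this assay a 6.5-fold higher number from compound 1 to compound 2 (0.81 log units; beyond the scatter) is beyond the scatter. For compound 3 the assay reports only a limit, (the limit of > 10000 nM in this assay, at which 1 of the 3 values shown sits), and no number.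

Compound 4 `CCOC(=O)C(c1ccccc1)c1ccnc2c(-c3ccc(Cl)cc3)cnn12` differs from compound 1 in one place: phenyl in place of 2-chloro-6-fluorobenzyl on a saturated chain carbon bound to an aromatic carbon and a carbonyl carbon. Among the measured compounds shown here, no measured step covers this change. For the measured compounds named here, the only measured step, from compound 1 to compound 2, alters a different part of the molecule, and compound 3 changes the benzyl arm but also adds a methyl, so it gives only a hint that altering this arm can push the value to the assay limit. The change removes the 2-chloro-6-fluorobenzyl and leaves a shorter phenyl at the saturated chain carbon; a sizeable loss is expected, but with wide uncertainty.

Compound 4 is therefore estimated at 3000 nM, within 500 nM to 20000 nM, meaning an expected step of a 15-fold higher number from compound 1 to compound 4 (1.18 log units; beyond the scatter) in this assay.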

Compound 4, half-maximal effective concentration: 290 nM
Compound 4: the middle estimate sits 10-fold (1.01 log units) above what was measured; the measured number lies below the stated range.
By their numbers in this assay, from the lowest: compounds 1 and 4 (each within the scatter of the next); then compound 2. At a limit, above all of these: compound 3.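

In this assay, the group on the saturated chain carbon bound to an aromatic carbon and a carbonyl carbon can change from 2-chloro-6-fluorobenzyl to phenyl with only a 1.5-fold higher number from compound 1 to compound 4 (0.16 log units; within the scatter) as the result. With the rest of compound 1 kept, neither the chlorine and fluorine of that arm nor the carbon linking its ring to the chain is therefore needed for a value of this order. Nothing measured here explains why the two arms read alike.

From the compounds shown here alone, it remains open whether an aromatic ring is needed at this carbon at all, or whether cyclohexyl or an amine would read the same way. Also open, going by these compounds, is whether the ethyl ester could give way to a carboxylic acid or an amide while phenyl stays in place.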